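Methylsulfanyl for cyano on the aryl of compound 3

This account rests on a few compounds, and the source may have more. Where it says the series, first, only, none or still open, it means among the compounds named here.

Measured compounds:
compound 1 `CC(C)OC(=O)N1CCC(Oc2ncnc3c2CCN3c2ccc(S(C)(=O)=O)cc2F)CC1` — 50.1 nM
compound 2 `Cc1ncccc1N1CCc2c(OC3CCN(C(=O)OC(C)C)CC3)ncnc21` — limit, > 10000 nM
compound 3 `CC(C)OC(=O)N1CCC(Oc2ncnc3c2CCN3c2ccc(C#N)c(F)c2)CC1` — 398 nM

In a functional assay on CHO-K1 cells for agonist activity at Glucose-dependent insulinotropic receptor (Homo sapiens), read by a luciferase reporter, with a stated time of 5 h (a lower number here means that less compound is needed, a higher number that more compound is needed for the effect), compound 3 gives 398 nM, the highest of the two numbers, with compound 1 at 50.1 nM. For compound 2 the value > 10000 nM is a limit, not a number (the limit of > 10000 nM in this assay, at which 1 of the 3 values shown sits). Compound 4 `CSc1ccc(N2CCc3c(OC4CCN(C(=O)OC(C)C)CC4)ncnc32)cc1F` differs from compound 3 by methylsulfanyl in place of cyano on an aromatic carbon. Among the measured compounds shown here, no measured step makes this change; the steps of a 7.9-fold higher number from compound 1 to compound 3 (0.90 log units; beyond the scatter) and an at least 25-fold lower number from compound 2 to compound 3 (1.40 log units; beyond the scatter) replace the whole aryl group, and the analogue of compound 1 also differs in where the fluoro sits. Compound 4 is therefore expected to show no step beyond the scatter, a 1.3-fold lower number from compound 3 to compound 4 (0.12 log units; within the scatter). Compound 4 is estimated at 300 nM, between 60 nM and 1500 nM.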

Compound 4, half-maximal effective concentration: 398 nM
For compound 4 the middle estimate is 1.3-fold (0.12 log units) below the measured one, within the range that was stated.
By their numbers in this assay, from the lowest: compound 1; then compounds 3 and 4 (each within the scatter of the next). At a limit, above all of these: compound 2.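

With no change at the digits printed from compound 3 to compound 4 (within the scatter) in this assay methylsulfanyl and cyano cannot be told apart on this aromatic carbon ortho to a fluoro group. The aryl changes behind a 7.9-fold higher number from compound 1 to compound 4 (0.90 log units; beyond the scatter) and an at least 25-fold lower number from compound 2 to compound 4 (1.40 log units; beyond the scatter) remain beyond the scatter, so this swap leaves the gaps to the other compounds as they were. The second of those steps starts from a limit, not a number: the limit of > 10000 nM in this assay, at which 1 of the 4 values shown sits.

The compounds shown leave open whether an amine or a carboxylic acid on this carbon would shift the number. They also leave open what methylsulfonyl would do here with the fluoro group kept in place.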